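This account rests on a few compounds, and the source may have more. Where it says the series, first, only, none or still open, it means among the compounds named here.

Compound 2, with the structure `COc1cc(Cl)cc(-c2nn(-c3cccc(NC(=O)Nc4ccc(Cl)c(C(F)(F)F)c4)c3)cc2-c2ccncc2)c1`, is the lower of the two numbers measured here. In a functional assay on MOLT-4 cells (Homo sapiens) for inhibition, read by sulforhodamine B assay, with a stated time of 48 h, tested at 100 uM (a lower number here means a stronger effect, a higher number a weaker effect of the compound at the concentration tested), compound 2 gives -28%, while compound 1, with the structure `O=C(Nc1cccc(-n2cc(-c3ccncc3)c(-c3cc(O)cc(Cl)c3)n2)c1)Nc1ccc(Cl)c(Cl)c1`, gives -10%, a difference beyond the usual scatter. Compound 3, with the structure `COc1cc(Cl)cc(-c2nn(-c3cccc(NC(=O)Nc4ccc(Cl)c(Cl)c4)c3)cc2-c2ccncc2)c1`, has not been measured. It differs from compound 2 by chloro in place of trifluoromethyl on an aromatic carbon. Compound 1 carries the same 3,4-dichlorophenyl group, though it also differs elsewhere. For compound 3 a small step toward a weaker effect is expected, a number 10 percentage points higher from compound 2 to compound 3 (within the scatter), roughly within the scatter. Compound 3 is therefore estimated at -18%, with a range from -38% to 4%.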

Compound 3, a percentage reported as activity, at one concentration (the size of the read-out at that concentration, not a potency): -7%
Compound 3: middle estimate off by 11 percentage points, on the low side, and the stated range covers the measured number.
By their numbers in this assay, from the lowest: compound 2; then compounds 1 and 3 (each within the scatter of the next).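

In this assay, this aromatic carbon proves sensitive to the change of group: chloro in place of trifluoromethyl gives a number 21 percentage points higher from compound 2 to compound 3 (beyond the scatter). With the 3,4-dichlorophenyl group in both compounds, methyl in place of hydrogen on the oxygen gives a number 3 percentage points higher from compound 1 to compound 3 (within the scatter), so that change has no readable effect here. Nothing available explains the first step. Going by these compounds, how bromo, methyl or a nitrile would read at this carbon remains open. So does whether the oxygen change would also leave the number unmoved alongside the 4-chloro-3-(trifluoromethyl)phenyl group.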